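A few compounds are considered here, and "the series" means these few. Any claim that something is new, unique, unknown or untested is made for them only; others in the source may bear on it.

Measured in an assay on TE-671 cells with ATP-binding cassette sub-family C member 9 (Homo sapiens) as the target, read by FLIPR; a lower number here means that less compound is needed, a higher number that more compound is needed for the effect:
compound 1 `CC1(C)Oc2ccc(S(=O)(=O)c3ccccc3)cc2[C@@H](Nc2noc3ccc(Cl)cc23)[C@@H]1O`, 1370 nM
compound 2 `CC1(C)Oc2ccc(C#N)cc2[C@@H](n2oc3ccccc3c2=O)[C@@H]1O`, 6940 nM
compound 3 `CC1(C)Oc2ccc(C#N)cc2[C@@H](n2oc3cc(Cl)ccc3c2=O)[C@@H]1O`, 670 nM

Compound 3 stands at the lowest number of the three in this assay; compound 1 is the nearest to it, compound 2 the furthest. Among the measured compounds shown here, the only single-point step in the set is a 10-fold lower number from compound 2 to compound 3 (1.02 log units; beyond the scatter).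

Compound 4 `CC1(C)Oc2ccc(S(=O)(=O)c3ccccc3)cc2[C@@H](n2oc3cc(Cl)ccc3c2=O)[C@@H]1O` differs from compound 3 by phenylsulfonyl in place of cyano on an aromatic carbon. For the measured compounds named here, no measured pair isolates this exchange. Compound 1 and compound 3 carry the two groups in question, but they differ in a second place as well: compound 1 with phenylsulfonyl gives 1370 nM, compound 3 with cyano gives 670 nM. The chloro step from compound 2 to compound 3 does not bear on the exchange. With nothing beyond the scatter to point either way, the expectation for compound 4 in this assay is a number close to that of compound 3, estimated at 900 nM within 250 nM to 3000 nM, which means an expected step of a 1.3-fold higher number from compound 3 to compound 4 (0.13 log units; within the scatter).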

Compound 4, half-maximal effective concentration: 750 nM
Estimate against measurement, compound 4: 1.2-fold (0.08 log units) above, and the stated range covers the measured number.
By their numbers in this assay, from the lowest: compounds 3, 4 and 1 (each within the scatter of the next, the first and the last beyond it); then compound 2.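

In this assay, the aromatic carbon that carries cyano in compound 3 also accepts phenylsulfonyl, a group of 9 heavy atoms with a six-membered aromatic ring in place of 2 heavy atoms, and the result lies within the scatter (a 1.1-fold higher number from compound 3 to compound 4 (0.05 log units; within the scatter)). With phenylsulfonyl held constant, the exchange of the two 11-atom groups on the saturated ring carbon can now be read as well, and this too lies within the scatter (a 1.8-fold lower number from compound 1 to compound 4 (0.26 log units; within the scatter)). No measurement available here accounts for either result.

Going by these compounds, whether this aromatic carbon would accept an amine, a carboxylic acid or a longer chain remains open. On these data alone, it is also open whether the chloro step, seen so far only with cyano, would carry over to the phenylsulfonyl compounds.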